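Trimming an alkenyl chain: from compound 2 to compound 3

This account rests on a few compounds, and the source may have more. Where it says the series, first, only, none or still open, it means among the compounds named here.

Compound 2 `C/C=C/C#Cc1ccc(CCC(=O)O)c(F)c1` gives 97% in a functional assay on 1321-N1 cells for agonist activity at Free fatty acid receptor 1 (Homo sapiens), read by calcium flux, with a stated time of 0.4 s (a higher number here means a larger maximal response, a lower number a smaller maximal response), the lower of the two numbers measured, with compound 1 `C/C=C(/C)C#Cc1ccc(CCC(=O)O)c(F)c1` at 103% close by. Among the compounds with values here, the one measured step, a number 6 percentage points lower from compound 1 to compound 2 (within the scatter), swapped one three-carbon alkenyl group for another on the triple-bonded carbon and stayed within the scatter. Compound 3 `C=C(C)C#Cc1ccc(CCC(=O)O)c(F)c1` carries a change of the same kind: 1-methylethenyl in place of prop-1-en-1-yl on a triple-bonded carbon. Within the data shown here, with only that step as a guide, no movement beyond the scatter is expected, so the step of a number 3 percentage points higher from compound 2 to compound 3 (within the scatter) is estimated to be small. Compound 3 is expected to reach 100%, between 85% and 115%.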

Compound 3, largest response reached (reported as efficacy), in percent of the reference or control that the assay uses: 106%
For compound 3 the middle estimate is 6 percentage points below the measured one; the measured number falls inside the stated range.
By their numbers in this assay, from the lowest: compounds 2, 1 and 3 (each within the scatter of the next).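

Placing 1-methylethenyl on the triple-bonded carbon gives a number 9 percentage points higher from compound 2 to compound 3 (within the scatter) and a number 3 percentage points higher from compound 1 to compound 3 (within the scatter) in the same comparison. All three alkenyl groups at this place therefore give maximal responses in this assay that cannot be told apart, whichever carbon of the double bond carries the methyl group. No supporting data bear on this result.

Open, on these data alone, is whether this tolerance extends beyond small alkenyl groups, for example to a longer alkyl chain or an amine at the same place. These numbers also leave open how much compound is needed to reach the response.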